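From a long-chain acid to a tert-butyl ester

The compounds below may be only part of what the source reports. "The series", "measured", "known", "first", "only" and "open" are said of these compounds alone.

In a functional assay for inhibition, with Homo sapiens as the target (on this read-out lower numbers stand for stronger inhibition and higher numbers for weaker inhibition), compound 1 `COC(=O)CCCCCCCCn1nc(-c2ccccc2)c(-c2ccccc2)c1-c1ccccc1`, which ends in methoxycarbonyl, gives 4300 nM, and compound 3 `O=C(O)CCCCCCCCCCn1nc(-c2ccccc2)c(-c2ccccc2)c1-c1ccccc1`, which ends in carboxy, gives 18600 nM. Compound 2 `O=C(O)CCCCCn1nc(-c2ccccc2)c(-c2ccccc2)c1-c1ccccc1`, a shorter-chain acid, gives > 78000 nM, which is a limit of the assay. Compound 3 therefore holds the higher of the two true numbers, with compound 1 as its nearest neighbour.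

Compound 4 `CC(C)(C)OC(=O)COCCCCCCn1nc(-c2ccccc2)c(-c2ccccc2)c1-c1ccccc1` is reached from compound 3 by one change: (tert-butoxycarbonyl)methoxy in place of 4-carboxybutyl on a saturated chain carbon, six bonds along the chain from an aromatic nitrogen. The free acid thus gives way to an ester, the kind of end group compound 1 carries. The step most relevant here is a 4.3-fold higher number from compound 1 to compound 3 (0.64 log units; beyond the scatter). Going by the values given here, it is only an indirect guide, since it joins an ester to an acid of different chain length, and no measured pair isolates the ester alone. The step of an at least 4.1-fold lower number from compound 2 to compound 3 (0.62 log units; beyond the scatter) and the step of an at least 18-fold higher number from compound 1 to compound 2 (1.25 log units; beyond the scatter) show that chain length and end group together can matter a great deal in this assay.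

On the strength of the step to compound 3 from compound 1, a modest move towards stronger inhibition is expected, read as a 2.7-fold lower number from compound 3 to compound 4 (0.42 log units; beyond the scatter). For compound 4 the estimated value is 7000 nM, with an expected range from 1800 nM to 30000 nM.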

Compound 4, half-maximal inhibitory concentration: > 62000 nM
Compound 4 gave a limit, no number (the forecaster's own chance of this, stated with the estimate: 15%); at least 8.8-fold (0.94 log units) between middle value and limit.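

In this assay, putting (tert-butoxycarbonyl)methoxy in place of 4-carboxybutyl, six bonds along the chain from an aromatic nitrogen, gives an at least 3.3-fold higher number from compound 3 to compound 4 (0.52 log units; beyond the scatter), so at this position, losing the free acid for this ester brings no gain and moves the read-out towards weaker inhibition. Set against the methoxycarbonyl ester, the same end of the chain gives an at least 14-fold higher number from compound 1 to compound 4 (1.15 log units; beyond the scatter), which shows that an ester end group alone does not secure the activity seen earlier, as the two ester-bearing compounds lie far apart. Compound 4 stands at a limit of the assay and not at a number, and compound 2 does too, so the step joining those two cannot be read: the limit of > 62000 nM in this assay, at which 1 of the 4 values shown sits.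

The change swaps the end group and also brings an oxygen into the chain, and the compounds shown do not separate these two parts. From the compounds shown here alone, a carboxymethoxy group or a (methoxycarbonyl)methoxy group at this place would tell whether the tert-butyl ester or the chain oxygen goes with the weaker read-out, and that question stays open here.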